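Acetylation of a Hydroxyl in a Cytotoxicity Series

This account rests on a few compounds, and the source may have more. Where it says the series, first, only, none or still open, it means among the compounds named here.

Compound 1 `C=C1C(=O)O[C@]2(C)CC[C@@H]1C[C@H](O)[C@@]1(C)CC[C@H](OC(C)=O)[C@@](C)(CCC2=O)O1`: in a functional assay on HeLa cells (Homo sapiens) for cytotoxicity (a lower number here means a stronger inhibitor, a higher number a weaker inhibitor), compound 1 gives > 20 ug/mL, which is a limit of the assay rather than a number.
Compound 2 `C=C1C(=O)O[C@]2(C)CC[C@@H]1C[C@H](OC(C)=O)[C@@]1(C)CC[C@H](O1)[C@](C)(O)CC[C@H]2OC(C)=O`: in this assay compound 2 gives > 20 ug/mL, again a limit.
Compound 3 `C=C1C(=O)O[C@]2(C)CC[C@@H]1C[C@H](O)[C@@]1(C)CC[C@H](O1)C(=C)CC[C@H]2OC(C)=O`: in this assay compound 3 gives > 20 ug/mL, also a limit.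

Among the compounds with values here, compound 3 therefore stands at the limit of > 20 ug/mL in this assay, at which 3 of the 3 values shown sit; no measured compound here has given a number, so no step between measured compounds can be read from these data, and nothing is known about how any of them acts on the cells.

Compound 4 `C=C1C(=O)O[C@]2(C)CC[C@@H]1C[C@H](OC(C)=O)[C@@]1(C)CC[C@H](O1)C(=C)CC[C@H]2OC(C)=O` is the next compound, and it differs from compound 3 by acetyl in place of hydrogen on an oxygen on a saturated carbon. Compounds 1 and 2 already carry acetoxy groups and still sit at the limit, so no shift beyond the usual scatter is expected in this assay from this change. The estimated step that the limit leaves unreadable from compound 3 to compound 4 is expected to be none beyond the scatter. Compound 4 is thus expected to give about 30 ug/mL, with a range from 12 ug/mL to 100 ug/mL, most likely again as a limit.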

Compound 4, half-maximal inhibitory concentration: > 20 ug/mL
Compound 4: no number, only a limit; the forecaster's own chance of this, stated with the estimate: 85%; the middle value is on the limit's open side.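

In this assay, within the data shown here, compound 3 and compound 4 both give limits rather than numbers, and no step between them can be read for the change from hydroxy to acetoxy. The compounds shown leave open how strongly any of them acts on these cells, and whether that change matters at all.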